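The compounds below may be only part of what the source reports. "The series", "measured", "known", "first", "only" and "open" are said of these compounds alone.

Three compounds measured in a functional assay on Jurkat cells (Homo sapiens) for cytotoxicity, read by luminescence and CellTiter-Glo, with a stated time of 3 days (on this read-out lower numbers stand for stronger inhibition and higher numbers for weaker inhibition), frame the question. Compound 1 `O=C(Nc1ccc(Cl)cc1Cl)c1ccc2cccnc2c1O` gives 430 nM in this assay, compound 3 `O=C(Nc1ccc(Cl)cc1)c1ccc2cccnc2c1O` gives 510 nM, and compound 2 `O=C(Nc1cccc(C(F)(F)F)c1)c1cc(F)ccc1O` gives 840 nM; all three numbers lie within the scatter of one another. Compound 1 and compound 3 share a core, and the change between them, (chloro in place of hydrogen on an aromatic carbon), produced a 1.2-fold lower number from compound 3 to compound 1 (0.07 log units; within the scatter). Compound 2 rests on a different core; the difference between the two cores is not broken down here. Compound 4 `O=C(Nc1ccc(Cl)c(C(F)(F)F)c1)c1cc(F)ccc1O` is not yet measured. It arises from compound 2 by chloro in place of hydrogen on an aromatic carbon, the same kind of change as that from compound 3 to compound 1, though here the entering chloro sits ortho to a trifluoromethyl group and para to a large group, whereas in compound 1 it sits ortho to a large group and meta to a chloro group. Given that the earlier step stayed within the scatter, the step from compound 2 to compound 4 in this assay is expected to be a 1.3-fold lower number from compound 2 to compound 4 (0.11 log units; within the scatter). Compound 4 is therefore estimated at 650 nM, with a range from 250 nM to 1700 nM.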

Compound 4, half-maximal inhibitory concentration: 530 nM
Beside the measured number, compound 4's estimate is 1.2-fold (0.09 log units) above it, and the stated range covers the measured number.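

In this assay, among the compounds shown here, the chloro change gives a 1.6-fold lower number from compound 2 to compound 4 (0.20 log units; within the scatter), and set beside the earlier case the two steps cannot be told apart: the same change on two cores in this assay, a 1.2-fold lower number (0.07 log units; within the scatter) from compound 3 to compound 1 and a 1.6-fold lower number (0.20 log units; within the scatter) from compound 2 to compound 4, 1.3-fold (0.13 log units) apart, within the scatter of two such steps This shows that, on these two cores, the change carried over without a detectable difference, even though in compound 4 the entering chloro sits ortho to a trifluoromethyl group and para to a large group, a different setting from the one it has in compound 1. It does not show that the chloro has a real effect or that the two steps are truly equal, since each lies within the scatter, and two pairs say nothing about other cores or other places on the ring.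

The compounds shown leave open whether a methoxy group, a nitrile or an amine entering at the same place on the core of compound 2 would give a step beyond the scatter. They also leave open whether the chloro change would stay this small on a third core.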